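Dichlorophenyl hydrazide and chlorophenyl oxadiazole sulfonamides

A few compounds are considered here, and "the series" means these few. Any claim that something is new, unique, unknown or untested is made for them only; others in the source may bear on it.

Measured in an assay on cells for inhibition of Amine oxidase [flavin-containing] A (Homo sapiens), read by fluorescence and spectrophotometry, using microsomes, with a stated time of 20 min; on this read-out lower numbers stand for stronger inhibition and higher numbers for weaker inhibition:
compound 1 — `NS(=O)(=O)c1ccc(C(=O)NNC(=O)c2ccc(Cl)c(Cl)c2)cc1` — 13600 nM
compound 2 — `NS(=O)(=O)c1cccc(-c2nnc(-c3ccc(Cl)cc3)o2)c1` — > 100000 nM
compound 3 — `NS(=O)(=O)c1ccc(-c2nnc(-c3ccc(Cl)cc3)o2)cc1` — 68000 nM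

Among the two numbers given, compound 1 stands lowest; the nearest, compound 3, sits higher by a margin beyond the usual scatter. Compound 2 returns no number, only a limit, > 100000 nM. That result is the limit of > 100000 nM in this assay, at which 1 of the 3 values shown sits.

Compound 4 `NS(=O)(=O)c1ccc(C(=O)NNC(=O)c2ccc(Cl)cc2)cc1` differs from compound 1 by hydrogen in place of chloro on an aromatic carbon. Within the data shown here, no measured pair covers this kind of change, so the size of the step is not known from the data. The expectation is a modest weakening, a 2.0-fold higher number from compound 1 to compound 4 (0.30 log units; within the scatter), well short of the limit. For compound 4 the estimate is 27000 nM, with a range of 9000 nM to 80000 nM.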

Compound 4, half-maximal inhibitory concentration: 55900 nM
For compound 4 the middle estimate is 2.1-fold (0.32 log units) below the measured one; measured number inside the range.
By their numbers in this assay, from the lowest: compound 1; then compounds 4 and 3 (each within the scatter of the next). At a limit, above all of these: compound 2.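

Going from 3,4-dichlorophenyl to 4-chlorophenyl gives the series its first measured size for this change in this assay: a 4.1-fold higher number from compound 1 to compound 4 (0.61 log units; beyond the scatter). The step lies beyond the scatter, so in this pair the chloro on this aromatic carbon goes with the lower number, a reading that rests on this one pair alone. Nothing shown gives a cause for the step.

From the compounds shown here alone, whether fluoro, methyl or methoxy at this position would keep the number of compound 1 stays open. So does whether the same change would give a similar step on the chlorophenyl oxadiazole sulfonamides.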